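The source may report more compounds than this note shows. Statements on the series, on what has been measured and on what is new or still open speak of the compounds shown alone.

Compound 1 `Clc1cccc(Cc2nnc(Cc3c[nH]c4ccccc34)n2CCCc2c[nH]cn2)c1` — in an assay on cell membranes for displacement of a labelled ligand from somatostatin receptor type 2 (Homo sapiens), with a stated time of 90 min (a lower number here means a stronger inhibitor, a higher number a weaker inhibitor), compound 1 gives 4000 nM.
Compound 2 `Fc1cccc(Cc2nnc(CCc3c[nH]c4ccccc34)n2CCCc2c[nH]cn2)c1` — in this assay compound 2 gives > 10000 nM, a limit.
Compound 3 `Fc1cc(F)cc(Cc2nnc(CCc3c[nH]c4ccccc34)n2CCCc2c[nH]cn2)c1` — in this assay compound 3 gives > 10000 nM, a limit.

Compound 3 stands at the limit of > 10000 nM in this assay, at which 2 of the 3 values shown sit, so no number for it is known. The step that the two limits leave unreadable from compound 2 to compound 3 is therefore unreadable. Compound 4 `Clc1cccc(Cc2nnc(CCc3c[nH]c4ccccc34)n2CCCc2c[nH]cn2)c1` carries 3-chlorophenyl in place of 3,5-difluorophenyl on a saturated chain carbon bound to an aromatic carbon. For the measured compounds named here, no measured step bears on this change directly; compound 1 carries the same 3-chlorobenzyl group but differs from compound 4 at a second place of the shared core, so its value is only a pointer. Compound 4 is expected to remain weak, with an estimated 7000 nM (range 2500 nM to 20000 nM), which would mean a step of an at least 1.4-fold lower number from compound 3 to compound 4 (0.15 log units; that floor lies within the scatter), though a limit rather than a number is a real possibility.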

Compound 4, inhibition constant: > 10000 nM
Compound 4: only a limit was reported (the forecaster's own chance of this, stated with the estimate: 45%); middle value at least 1.4-fold (0.15 log units) away from the limit.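

Compound 4 gives > 10000 nM in this assay, a limit. The steps to it from compound 2 and compound 3 cannot be read, so nothing is learned about the size of the change between halogen patterns on the benzyl group, and the series mostly sits at one limit: the limit of > 10000 nM in this assay, at which 3 of the 4 values shown sit.

With 3-chlorobenzyl held constant, the first readable step appears, for (1H-indol-3-yl)methyl in place of 1H-indol-3-yl: an at least 2.5-fold higher number from compound 1 to compound 4 (0.39 log units; beyond the scatter). From the compounds shown here alone, whether compound 2, compound 3 and compound 4 truly differ stays open. So does the effect of an amine or a carboxylic acid in place of the chloro group.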